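Replacing pyrazin-2-yl with 4-cyanophenyl on the ring nitrogen

The source may report more compounds than this note shows. Statements on the series, on what has been measured and on what is new or still open speak of the compounds shown alone.

Measured in a functional assay on MGC-803 cells (Homo sapiens) for antiproliferative activity, read by CCK-8 assay, with a stated time of 72 h, tested at 2 uM; on this read-out higher numbers stand for a stronger effect at the one concentration tested and lower numbers for a weaker effect:
compound 1 `Nc1ccccc1NC(=O)c1ccc(CSC(=S)N2CCN(Cc3ccncc3)CC2)cc1` gives 18.4%
compound 2 `COc1ccc(N2CCN(C(=S)SCc3ccc(C(=O)Nc4ccccc4N)cc3)CC2)cc1` gives 25.3%
compound 3 `Nc1ccccc1NC(=O)c1ccc(CSC(=S)N2CCN(c3cnccn3)CC2)cc1` gives 27.1%

Compound 3 has the highest of the three numbers, but its gaps to the other two are small: a number 1.8 percentage points higher from compound 2 to compound 3 (within the scatter) and a number 8.7 percentage points higher from compound 1 to compound 3 (within the scatter) both stay within the scatter, as does a number 6.9 percentage points higher from compound 1 to compound 2 (within the scatter). The three compounds share one core and differ only in the group on the amine nitrogen in the ring.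

Compound 4 `N#Cc1ccc(N2CCN(C(=S)SCc3ccc(C(=O)Nc4ccccc4N)cc3)CC2)cc1` keeps that core and changes the same spot: 4-cyanophenyl in place of pyrazin-2-yl on an amine nitrogen in a ring. All three measured steps concern this position, and none moved the inhibition beyond the scatter. Compound 2, which carries a 4-methoxyphenyl there, is the closest measured relative of compound 4, and its value sits close to that of compound 3. The expected step of a number 2.1 percentage points lower from compound 3 to compound 4 (within the scatter) is therefore small, with no clear direction beyond the scatter. Compound 4 is estimated at 25%, with a likely range from 10% to 42%.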

Compound 4, a percentage reported as inhibition, at one concentration (the size of the read-out at that concentration, not a potency): 34.5%
Compound 4: middle estimate off by 9.5 percentage points, on the low side, within the range that was stated.
By their numbers in this assay, from the lowest: compounds 1, 2, 3 and 4 (each within the scatter of the next, the first and the last beyond it).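

In this assay this position gives its first step beyond the scatter, with a number 16.1 percentage points higher from compound 1 to compound 4 (beyond the scatter) when 4-cyanophenyl replaces (pyridin-4-yl)methyl on the amine nitrogen in the ring. The steps of a number 7.4 percentage points higher from compound 3 to compound 4 (within the scatter) and a number 9.2 percentage points higher from compound 2 to compound 4 (within the scatter) both stay within the scatter, so neither pyrazin-2-yl to 4-cyanophenyl nor methoxy to cyano on the aromatic carbon can be told apart from repeat-to-repeat noise. Within the data shown here, nothing measured here gives a reason for the one larger step.

The compounds shown leave open whether a plain phenyl, or a phenyl carrying an amine or a carboxylic acid where the cyano sits, would fall with compound 4 or with compound 1. Also open, going by these compounds, is whether a 4-cyanobenzyl group on the same nitrogen would keep the level of compound 4 or drop towards that of compound 1.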